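Methyl for Methoxy: Compound 4 in the Cytotoxicity Series

A few compounds are considered here, and "the series" means these few. Any claim that something is new, unique, unknown or untested is made for them only; others in the source may bear on it.

Of the compounds shown here, three that share one core have been measured in an ADME assay on MCF-10A cells (Homo sapiens) for cytotoxicity, read by MTT assay, with a stated time of 24 h; a higher number here means a weaker inhibitor, a lower number a stronger inhibitor. Compound 1 `COc1ccc(-c2cc(COc3ccccc3-c3nc4ccccc4s3)on2)cc1` gives 34100 nM. Compound 2 `c1ccc(-n2cc(COc3ccccc3-c3nc4ccccc4s3)nn2)cc1` gives 36400 nM, and compound 3 `Fc1ccc(-n2cc(COc3ccccc3-c3nc4ccccc4s3)nn2)cc1Cl` gives 26300 nM. Compound 1 stands second highest of the three numbers; its nearest neighbour is compound 2 and its furthest is compound 3, and both gaps lie within the scatter, so the three compounds cannot be separated on these numbers. For the measured compounds named here, the only step between two measured compounds, a 1.4-fold lower number from compound 2 to compound 3 (0.14 log units; within the scatter), concerns a group on an aromatic nitrogen and also stays within the scatter.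

Compound 4 `Cc1ccc(-c2cc(COc3ccccc3-c3nc4ccccc4s3)on2)cc1` differs from compound 1 by methyl in place of methoxy on an aromatic carbon. Going by the values given here, no measured step concerns an exchange of this kind on this ring, and the one step in hand, between compound 2 and compound 3, lies within the scatter. Among the compounds with values here, with no measured step pointing beyond the scatter in either direction, compound 4 is expected to stand close to compound 1, with a step of a 1.0-fold lower number from compound 1 to compound 4 (0.01 log units; within the scatter). Compound 4 is therefore estimated at 33000 nM in this assay, within a range from 17000 nM to 66000 nM.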

Compound 4, half-maximal inhibitory concentration: 26400 nM
The estimate for compound 4 lay 1.3-fold (0.10 log units) above the measured number, and the stated range covers the measured number.
By their numbers in this assay, from the lowest: compounds 3, 4, 1 and 2 (each within the scatter of the next).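

In this assay, for the compounds shown here, the change from 4-methoxyphenyl to 4-methylphenyl gives the first reading at this place, on an aromatic carbon para to a large group, and the step is a 1.3-fold lower number from compound 1 to compound 4 (0.11 log units; within the scatter) so that compound 1 and compound 4 cannot be separated on these numbers. Methyl carries no hydrogen-bond acceptor where methoxy carries one, and one heavy atom fewer stands at this place, yet neither difference brings the step beyond the scatter in this assay, so the earlier reading on the group on an aromatic nitrogen is now joined by a second one, at a different place, that also stays inside it. No measurement of any property of these two groups accompanies the result, and nothing can be said about what lies behind the small step.

As far as these compounds go, whether any group at this place can move the number beyond the scatter remains open, for instance an amine, a carboxylic acid or a longer chain in place of the methyl of compound 4. Also open, from the compounds shown here alone, is whether the same exchange of methoxy for methyl would read alike on the aryl group of compound 2 or compound 3, whose shared core differs from that of compound 1.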